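Methyl for chloro in a chalcone series at the limit

The source may report more compounds than this note shows. Statements on the series, on what has been measured and on what is new or still open speak of the compounds shown alone.

Compound 1 `CC1(C)Cc2c(OCc3ccccc3)ccc(C(=O)/C=C/c3ccc(Br)cc3)c2O1` gives in a functional assay on HT-29 cells (Homo sapiens) for antiproliferative activity, read by MTT assay, with a stated time of 48 h (a lower number here means a stronger inhibitor, a higher number a weaker inhibitor), only a limit, > 100000 nM. Compound 2 `CC1(C)Cc2c(ccc(C(=O)/C=C/c3cn(-c4ccccc4)nc3-c3cccc([N+](=O)[O-])c3)c2OCc2ccccc2)O1` likewise returns only a limit, > 100000 nM. Compound 3 `CC1(C)Cc2c(ccc(C(=O)/C=C/c3cn(-c4ccccc4)nc3-c3ccc(Cl)cc3)c2OCc2ccccc2)O1` stands at the same limit, > 100000 nM. The step that the two limits leave unreadable from compound 2 to compound 3 is therefore not readable, and compound 3 cannot be placed against the other two beyond this: the limit of > 100000 nM in this assay, at which 3 of the 3 values shown sit. Compound 4 `Cc1ccc(-c2nn(-c3ccccc3)cc2/C=C/C(=O)c2ccc3c(c2OCc2ccccc2)CC(C)(C)O3)cc1` differs from compound 3 by methyl in place of chloro on an aromatic carbon. No measured step speaks to this exchange, and the single step shown is itself unreadable, so the expected step is estimated as a number no higher from compound 3 to compound 4 (the limit leaves the size open). Compound 4 is expected most likely to return only a limit again in this assay, with an estimate of about 100000 nM, between 30000 nM and 300000 nM.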

Compound 4, half-maximal inhibitory concentration: > 100000 nM
Compound 4: only a limit was reported; the forecaster's own chance of this, stated with the estimate: 85%; the middle value sits exactly at the limit.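

Compound 4 returns only a limit, > 100000 nM, so the steps to compound 4 from compound 2 and compound 3 cannot be read. The compounds shown leave open whether any of these exchanges alters activity in this assay: the limit of > 100000 nM in this assay, at which 4 of the 4 values shown sit.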